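A 4-methylpiperidin-1-yl exchange on a shared core

The source may report more compounds than this note shows. Statements on the series, on what has been measured and on what is new or still open speak of the compounds shown alone.

In a functional assay on A549 cells (Homo sapiens) for inhibition, read by MTT assay, with a stated time of 72 h (on this read-out lower numbers stand for stronger inhibition and higher numbers for weaker inhibition), compound 1 (`CCc1nc2c(C)cc(-c3ccc(CN4CCC[C@H]4CO)cc3)cn2c1NC(=O)OCc1cc(Cl)cc(Cl)c1`) gives 5780 nM and compound 2 (`CCc1nc2c(C)cc(-c3ccc(CN4CCN(C)CC4)cc3)cn2c1NC(=O)OCc1cc(Cl)cc(Cl)c1`) gives 4020 nM. Going by the values given here, compound 2 therefore stands level with compound 1, the only other measured compound, with neither separated from the other by more than the usual scatter. Compound 3 (`CCc1nc2c(C)cc(-c3ccc(CN4CCC(C)CC4)cc3)cn2c1NC(=O)OCc1cc(Cl)cc(Cl)c1`) has 4-methylpiperidin-1-yl in place of 4-methylpiperazin-1-yl on a saturated chain carbon bound to an aromatic carbon. No measurement covers this exact exchange. Among the compounds with values here, the one measured step at this place involves a different pair of groups, and it is small: a 1.4-fold lower number from compound 1 to compound 2 (0.16 log units; within the scatter). On that limited evidence, no step beyond the scatter is expected in this assay. The estimated step is a 1.1-fold lower number from compound 2 to compound 3 (0.06 log units; within the scatter). For compound 3, the expected value is 3500 nM, within an estimated range of 1500 nM to 8000 nM.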

Compound 3, half-maximal inhibitory concentration: 8180 nM
Compound 3: the middle estimate sits 2.3-fold (0.37 log units) below what was measured; measured number above the stated range.
By their numbers in this assay, from the lowest: compounds 2, 1 and 3 (each within the scatter of the next, the first and the last beyond it).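

In this assay, putting 4-methylpiperidin-1-yl in place of 4-methylpiperazin-1-yl on a saturated chain carbon bound to an aromatic carbon gives a 2.0-fold higher number from compound 2 to compound 3 (0.31 log units; beyond the scatter) and so shows, as the earlier pair could not, that the number at this place can move beyond the scatter, if only modestly, when one ring nitrogen is exchanged for carbon. The step from the 2-(hydroxymethyl)pyrrolidin-1-yl group to the same 4-methylpiperidin-1-yl group is a 1.4-fold higher number from compound 1 to compound 3 (0.15 log units; within the scatter) and leaves those two groups unseparated. Nothing available explains why the ring nitrogen exchange shifts the number.

As far as these compounds go, whether a morpholine ring or an open-chain dimethylamino group at this place would fall with compound 2 or compound 3 remains open. From the compounds shown here alone, it is also open whether the same exchange would give a step of similar size on another core.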